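The compounds below may be only part of what the source reports. "The series", "measured", "known", "first", "only" and "open" are said of these compounds alone.

Measured so far:
compound 1, `Cc1cccc(-n2cc(-c3ccccc3NS(=O)(=O)c3c[nH]c(=O)[nH]c3=O)nn2)c1`: 3510 nM
compound 2, `O=c1[nH]cc(S(=O)(=O)Nc2ccccc2-c2cn(-c3ccc(F)cc3)nn2)c(=O)[nH]1`: > 20000 nM

Compound 1 gives the only number shown in a functional assay on SGC-7901 cells (Homo sapiens) for antiproliferative activity, read by MTT assay, with a stated time of 24 h; a lower number here means a stronger inhibitor, a higher number a weaker inhibitor; the other value is a limit. Compound 2 sits at the limit of > 20000 nM in this assay, at which 1 of the 2 values shown sits, so its result is a limit of the assay rather than a number. Compound 3, `O=c1[nH]cc(S(=O)(=O)Nc2ccccc2-c2cn(-c3ccc(Cl)cc3)nn2)c(=O)[nH]1`, has not yet been measured in this assay. It differs from compound 1 in one place: 4-chlorophenyl in place of 3-methylphenyl on an aromatic nitrogen. Within the data shown here, the one measured step that bears on this change is an at least 5.6-fold higher number from compound 1 to compound 2 (0.75 log units; beyond the scatter), where a 4-fluorophenyl replaced the same 3-methylphenyl on an aromatic nitrogen. A 4-chlorophenyl on that aromatic nitrogen is expected to move the number in the same direction. Compound 3 is therefore expected to give 12000 nM, between 4000 nM and 40000 nM, with a fair chance that only a limit is reported. This estimate corresponds to a 3.4-fold higher number from compound 1 to compound 3 (0.53 log units; beyond the scatter), a weakening expected to lie beyond the scatter.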

Compound 3, half-maximal inhibitory concentration: 2700 nM
Estimate against measurement, compound 3: 4.4-fold (0.65 log units) above; measured number outside the range, below it.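

In this assay, a 4-chlorophenyl on the aromatic nitrogen serves as well as a 3-methylphenyl, with a 1.3-fold lower number from compound 1 to compound 3 (0.11 log units; within the scatter), so the two groups cannot be told apart here. The loss seen with the 4-fluorophenyl is therefore not general to a substituted phenyl at this place, since chloro in place of fluoro on the same aromatic carbon gives an at least 7.4-fold lower number from compound 2 to compound 3 (0.86 log units; beyond the scatter). The result for compound 2 is a limit of the assay and not a number, so this step has no measured far end: the limit of > 20000 nM in this assay, at which 1 of the 3 values shown sits.

The compounds shown leave open whether a 4-bromophenyl or a 4-methylphenyl would stay with compound 1 and compound 3 or fall with compound 2. They also leave open how a 3-chlorophenyl or an unsubstituted phenyl would compare at this nitrogen.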